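The compounds below may be only part of what the source reports. "The series", "measured", "known", "first", "only" and "open" are said of these compounds alone.

Compounds measured in an assay on isolated protein (Cricetulus griseus) for inhibition of aldehyde dehydrogenase, mitochondrial (Homo sapiens); a higher number here means a weaker inhibitor, a lower number a stronger inhibitor:
- compound 1, `O=c1c(-c2ccc(O)cc2)coc2cc(OCCCCCCBr)ccc12`: 300 nM
- compound 2, `O=c1c(-c2ccc(O)cc2)coc2cc(OCCC3OCCCO3)ccc12`: 400 nM

Compound 2 holds the higher of the two numbers, but the step of a 1.3-fold higher number from compound 1 to compound 2 (0.12 log units; within the scatter) lies within the scatter, so the two are not separated. Compound 3 is `O=c1c(-c2ccc(O)cc2)coc2cc(OCCCBr)ccc12`; relative to compound 2 it carries a group of 2 heavy atoms (1 carbon, 1 bromine; no ring) in place of a group of 6 heavy atoms (4 carbon, 2 oxygen; one six-membered non-aromatic ring with 2 hetero atoms), on a saturated chain carbon, two bonds along the chain from an oxygen on an aromatic ring. Among the measured compounds shown here, the one step that bears on this exchange is a 1.3-fold higher number from compound 1 to compound 2 (0.12 log units; within the scatter), which swapped a bromine-bearing chain for the ring group without a movement beyond the scatter. The reverse exchange, to a bromomethyl group, is therefore expected to give no step beyond the scatter, a 1.3-fold lower number from compound 2 to compound 3 (0.10 log units; within the scatter). Compound 3 is estimated at 320 nM in this assay, with a range of 150 nM to 700 nM.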

Compound 3, half-maximal inhibitory concentration: 260 nM
Compound 3: middle estimate off by 1.2-fold (0.09 log units), on the high side, within the range that was stated.
By their numbers in this assay, from the lowest: compounds 3, 1 and 2 (each within the scatter of the next).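

In this assay the place on a saturated chain carbon, two bonds along the chain from an oxygen on an aromatic ring, now accepts bromomethyl as well as the ring group, with a 1.5-fold lower number from compound 2 to compound 3 (0.19 log units; within the scatter) as the step. Bromo in place of 3-bromopropyl gives a 1.2-fold lower number from compound 1 to compound 3 (0.06 log units; within the scatter) and so the shorter and longer bromine-bearing chains are not separated either. No measurement on hand explains why these chains and the ring group sit so close. From the compounds shown here alone, whether an amine or a carboxylic acid at this place would give a step beyond the scatter remains open.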